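A few compounds are considered here, and "the series" means these few. Any claim that something is new, unique, unknown or untested is made for them only; others in the source may bear on it.

Compound 3 `COc1cc2ncnc(Nc3ccc(NC(=O)c4ccccc4Cl)cc3)c2cc1OC` gives 26000 nM in a functional assay on HepG2 cells (Homo sapiens) for inhibition, read by MTT assay (a higher number here means a weaker inhibitor, a lower number a stronger inhibitor), the highest of the two numbers recorded, but its nearest neighbour compound 1 `COc1cc2ncnc(Nc3ccc(NC(=O)c4ccc(C)cc4)cc3)c2cc1OC`, which gives 25000 nM, is separated from it only by a 1.0-fold higher number from compound 1 to compound 3 (0.02 log units; within the scatter). Compound 2 `COc1cc2ncnc(Nc3ccc(NC(=O)c4ccc(C(C)(C)C)cc4)cc3)c2cc1OC` gives > 100000 nM in this assay, which is a limit of the assay and not a number. The step from compound 1 to compound 2 is an at least 4.0-fold higher number from compound 1 to compound 2 (0.60 log units; beyond the scatter), and the step from compound 2 to compound 3 is an at least 3.8-fold lower number from compound 2 to compound 3 (0.58 log units; beyond the scatter).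

Compound 4 `COc1cc2ncnc(Nc3ccc(NC(=O)c4ccc(C(F)(F)F)cc4)cc3)c2cc1OC` differs from compound 3 in one place: 4-(trifluoromethyl)phenyl in place of 2-chlorophenyl on a carbonyl carbon. Going by the values given here, the step that bears on it is the one from compound 1 to compound 2, where tert-butyl in place of methyl on the aromatic carbon raised the number beyond the scatter; compound 4 likewise carries a larger group than methyl on its phenyl at the carbonyl carbon. A modestly higher number is therefore expected, a 1.7-fold higher number from compound 3 to compound 4 (0.24 log units; within the scatter). Compound 4 is expected to give about 45000 nM in this assay, within a range of 15000 nM to 150000 nM.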

Compound 4, half-maximal inhibitory concentration: > 100000 nM
Compound 4: only a limit was reported; the forecaster's own chance of this, stated with the estimate: 25%; middle value at least 2.2-fold (0.34 log units) from the limit.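

Until now only tert-butyl had moved the number beyond the scatter. Trifluoromethyl in place of methyl on an aromatic carbon now does so as well, giving an at least 4.0-fold higher number from compound 1 to compound 4 (0.60 log units; beyond the scatter), and 4-(trifluoromethyl)phenyl in place of 2-chlorophenyl on a carbonyl carbon gives an at least 3.8-fold higher number from compound 3 to compound 4 (0.58 log units; beyond the scatter), whereas the earlier swap between 2-chlorophenyl and 4-methylphenyl stayed within the scatter. The step between compound 2 and compound 4 cannot be read, so tert-butyl and trifluoromethyl cannot be ranked in this assay, because both compounds stop at a limit of the assay and give no number: the limit of > 100000 nM in this assay, at which 2 of the 4 values shown sit.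

The compounds shown leave open how far beyond that limit either compound lies. They also leave open whether an amine or a carboxylic acid in place of the methyl on that aromatic carbon would keep the number near that of compound 1 or raise it likewise.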